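This account rests on a few compounds, and the source may have more. Where it says the series, first, only, none or still open, it means among the compounds named here.

In an assay (strain Wistar) for displacement of a labelled ligand from adenosine receptor A1 (Rattus norvegicus), read by scintillation counting (on this read-out lower numbers stand for stronger inhibition and higher numbers for weaker inhibition), three compounds have been measured so far:

Compound 1, `O=C(Nc1nc(-c2ccccc2)nc2c1nnn2Cc1ccccc1)C1CCCC1`: 2.5 nM
Compound 2, `O=C(Nc1nc(-c2ccccc2)nc2c1nnn2Cc1ccccc1)c1ccc(Cl)cc1`: 108 nM
Compound 3, `O=C(Nc1nc(-c2ccccc2)nc2c1nnn2Cc1ccccc1)C1CC1`: 7.5 nM

On these numbers compound 3 stands second highest of the three. Nearest to it is compound 1, the step being a 3.0-fold higher number from compound 1 to compound 3 (0.48 log units; beyond the scatter). Furthest from it is compound 2, with a 14-fold lower number from compound 2 to compound 3 (1.16 log units; beyond the scatter).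

Compound 4, `O=C(Nc1nc(-c2ccccc2)nc2c1nnn2Cc1ccccc1)c1ccccc1F`, differs from compound 3 in one place: 2-fluorophenyl in place of cyclopropyl on a carbonyl carbon. For the measured compounds named here, two measured steps bear on an aryl group replacing a cycloalkyl on this carbonyl carbon. The first is a 43-fold higher number from compound 1 to compound 2 (1.64 log units; beyond the scatter); the second is a 14-fold lower number from compound 2 to compound 3 (1.16 log units; beyond the scatter). Both are large and both place the aryl compound at the far higher number. Those steps concern a 4-chlorophenyl, whereas compound 4 carries a 2-fluorophenyl, so the size is uncertain, but the direction expected is a clearly higher number, beyond the scatter. Compound 4 is therefore expected to give 60 nM in this assay, with a range from 15 nM to 250 nM. The expected step is an 8.0-fold higher number from compound 3 to compound 4 (0.90 log units; beyond the scatter).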

Compound 4, inhibition constant: 40 nM
Beside the measured number, compound 4's estimate is 1.5-fold (0.18 log units) above it; low and high end bracket the measured number.
By their numbers in this assay, from the lowest: compound 1; then compound 3; then compound 4; then compound 2.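

In this assay, the second aryl group on this carbonyl carbon also falls on the weaker side of both cycloalkyl groups, with a 5.3-fold higher number from compound 3 to compound 4 (0.73 log units; beyond the scatter) and a 16-fold higher number from compound 1 to compound 4 (1.20 log units; beyond the scatter), so this order no longer rests on compound 2 alone. The two aryl groups are not interchangeable either, with a 2.7-fold lower number from compound 2 to compound 4 (0.43 log units; beyond the scatter), although that change alters both the halogen and the place it occupies on the phenyl ring, so the two effects cannot be separated. No measurement at hand explains these differences.

The compounds shown leave open where a plain phenyl, a 2-chlorophenyl or a 4-fluorophenyl would fall among these values, and so which part of the aryl change carries the step. They also leave open whether a cyclobutyl group or a straight alkyl chain on this carbonyl carbon would follow the cycloalkyl values.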